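Acyl variation at the side-chain ester of compound 1

This account rests on a few compounds, and the source may have more. Where it says the series, first, only, none or still open, it means among the compounds named here.

Measured so far:
compound 1 `CC[C@](C)(O)CC(=O)O[C@H](CC=C(C)C)C1=CC(=O)c2c(O)ccc(O)c2C1=O`: 30200 nM
compound 2 `CC(C)=CC[C@@H](OCC(C)O)C1=CC(=O)c2c(O)ccc(O)c2C1=O`: 24700 nM
compound 3 `CC(C)=CC[C@@H](OCCO)C1=CC(=O)c2c(O)ccc(O)c2C1=O`: 18600 nM

All three were run in a functional assay on HeLa cells (Homo sapiens) for cytotoxicity, read by MTT assay; on this read-out higher numbers stand for weaker inhibition and lower numbers for stronger inhibition. Compound 1 gives the largest of the three numbers, but a 1.2-fold lower number from compound 1 to compound 2 (0.09 log units; within the scatter) and a 1.6-fold lower number from compound 1 to compound 3 (0.21 log units; within the scatter) are both within the scatter, as is a 1.3-fold lower number from compound 2 to compound 3 (0.12 log units; within the scatter), so the three are not separable.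

Compound 4 `CC(C)=CC[C@@H](OC(=O)CC(C)(O)c1ccccc1)C1=CC(=O)c2c(O)ccc(O)c2C1=O` is unmeasured. It differs from compound 1 as follows: 1-hydroxy-1-phenylethyl in place of 1-hydroxy-1-methylpropyl on a saturated chain carbon bound to a carbonyl carbon. For the measured compounds named here, no measured step touches this position; the closest evidence is that swapping the whole (2-hydroxy-2-methylbutyl)carbonyl for 2-hydroxypropyl or 2-hydroxyethyl moved nothing beyond the scatter. The exchange of 1-hydroxy-1-methylpropyl for 1-hydroxy-1-phenylethyl is therefore expected to give a 1.0-fold lower number from compound 1 to compound 4 (0.00 log units; within the scatter), and compound 4 is estimated at 30000 nM (range 12000 nM to 75000 nM).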

Compound 4, half-maximal inhibitory concentration: 85700 nM
The estimate for compound 4 lay 2.9-fold (0.46 log units) below the measured number, outside the stated range (above it).
By their numbers in this assay, from the lowest: compounds 3, 2 and 1 (each within the scatter of the next); then compound 4.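

In this assay the exchange of 1-hydroxy-1-methylpropyl for 1-hydroxy-1-phenylethyl gives a 2.8-fold higher number from compound 1 to compound 4 (0.45 log units; beyond the scatter) and is the only step shown that lies beyond the scatter. This position therefore responds to the group it carries, and the change goes towards weaker inhibition, even though the earlier replacements of the whole acyl group separated nothing. No evidence on hand accounts for this step.

On these data alone, whether the aromatic ring itself or only the larger group matters stays open. A cyclohexyl group in place of the phenyl would separate these two readings.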